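The source may report more compounds than this note shows. Statements on the series, on what has been measured and on what is new or still open speak of the compounds shown alone.

Measured so far in a functional assay on A549 cells (Homo sapiens) for cytotoxicity, read by MTT assay, with a stated time of 72 h; on this read-out lower numbers stand for stronger inhibition and higher numbers for weaker inhibition:
- compound 1, `CN(C)CCn1cnnc1-c1cc(Oc2ccc(NC(=O)N/N=C/c3ccc(F)cc3Cl)cc2F)ccn1`: 1120 nM
- compound 2, `CN(C)CCn1cnnc1-c1cc(Oc2ccc(NC(=O)N/N=C/c3ccc(O)c(F)c3)cc2F)ccn1`: 13400 nM

Within the data shown here, compound 2 holds the higher of the two numbers: in this assay compound 2 gives 13400 nM, and the one measured step, a 12-fold higher number from compound 1 to compound 2 (1.08 log units; beyond the scatter), separates it from compound 1. Compound 3, `CN(C)CCn1cnnc1-c1cc(Oc2ccc(NC(=O)N/N=C/c3ccc(O)c(Br)c3)cc2F)ccn1`, is not yet measured. It differs from compound 2 by bromo in place of fluoro on an aromatic carbon. Among the measured compounds shown here, no measured step changes a single halogen on the 4-hydroxyphenyl ring; the only step known, a 12-fold higher number from compound 1 to compound 2 (1.08 log units; beyond the scatter), exchanges the whole aryl group and so bears on compound 3 only loosely, through compound 1 carrying a chloro rather than a fluoro. On that slender ground the expected step of a 1.5-fold lower number from compound 2 to compound 3 (0.17 log units; within the scatter) is small and towards a lower number, close to the scatter. Compound 3 is therefore estimated at 9000 nM in this assay, with a range from 3000 nM to 30000 nM.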

Compound 3, half-maximal inhibitory concentration: 1370 nM
Compound 3: middle estimate off by 6.6-fold (0.82 log units), on the high side, and the stated range ends above it.
By their numbers in this assay, from the lowest: compounds 1 and 3 (each within the scatter of the next); then compound 2.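

Replacing only the fluoro ortho to a hydroxy group with bromo gives a 9.8-fold lower number from compound 2 to compound 3 (0.99 log units; beyond the scatter) in this assay, so this single halogen exchange alone produces a change beyond the scatter, which the earlier exchange of the whole aryl group could not isolate. The 3-bromo-4-hydroxyphenyl group also proves comparable to the 2-chloro-4-fluorophenyl group, with a 1.2-fold higher number from compound 1 to compound 3 (0.09 log units; within the scatter), so the high number of compound 2 does not follow from the 4-hydroxyphenyl ring alone. No available evidence accounts for the difference between fluoro and bromo at this position.

From the compounds shown here alone, with only two substituents compared here, it remains open where chloro, iodo or a methyl group would fall at this position. Going by these compounds, it is also open how a methoxy group in place of the hydroxy group would read alongside the bromo.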